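Replacing the amide group of compound 1

This account rests on a few compounds, and the source may have more. Where it says the series, first, only, none or still open, it means among the compounds named here.

Measured in a functional assay on CLL cells (Homo sapiens) for cytotoxicity, read by MTT assay, with a stated time of 48 h; on this read-out lower numbers stand for an effect already at smaller amounts and higher numbers for an effect only at larger amounts of compound:
- Compound 1 `C=C(CC)C(=O)c1ccc(OCC(=O)Nc2nc3ccccc3s2)c(Cl)c1Cl`: 1500 nM
- Compound 2 `C=C(CC)C(=O)c1ccc(OCC(=O)Nc2ccc(C(=O)O)c(O)c2)c(Cl)c1Cl`: > 25000 nM (a limit of the assay, not a number)

Within the data shown here, compound 1 gives the only actual number in this assay, 1500 nM. The entry for compound 2, > 25000 nM, is a limit.

Compound 3 `C=C(CC)C(=O)c1ccc(OCC(=O)Nc2ccc3nc[nH]c3c2)c(Cl)c1Cl` has not been measured yet. It keeps the core of compound 1 and changes one group, with 1H-benzimidazol-6-yl in place of 1,3-benzothiazol-2-yl on an amide-type nitrogen. Each group has one five-membered aromatic ring with 2 hetero atoms, one six-membered aromatic ring of carbon only, and no net charge.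

Among the measured compounds shown here, no measured pair of compounds shows what a single change of this kind does, so the expectation rests on the structural change alone, starting from compound 1 at 1500 nM. In this assay, a moderate move towards a higher number, meaning a weaker effect, seems more likely than no change. The estimated step is a 3.0-fold higher number from compound 1 to compound 3 (0.48 log units; beyond the scatter), slightly beyond the usual scatter. For compound 3 the expected value is 4500 nM, with an estimated range from 1500 nM to 15000 nM.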

Compound 3, half-maximal effective concentration: 3200 nM
For compound 3 the middle estimate is 1.4-fold (0.15 log units) above the measured one, within the range that was stated.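

In this assay, placing 1H-benzimidazol-6-yl instead of 1,3-benzothiazol-2-yl on the amide-type nitrogen gives a 2.1-fold higher number from compound 1 to compound 3 (0.33 log units; beyond the scatter) and is a modest loss of effect. Among these compounds, this is the first actual step seen at this position, and it shows that the group can change without the value leaving the measurable range, with compound 3 at 3200 nM. The two groups have the same number of heavy atoms and the same types of ring, but they differ in sulfur against nitrogen and in their hydrogen-bond donors and acceptors, so a change of this kind costs little here. Among the compounds shown here, compound 2, with another group on the same nitrogen, gives only a limit and not a number, so no step to it can be read: (the limit of > 25000 nM in this assay, at which 1 of the 3 values shown sits).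

A single step cannot show which difference between the two groups matters, since the sulfur, the hydrogen-bond donors and acceptors, and the point of attachment implied by their names all change together. Still open, going by these compounds, is what a 1,3-benzoxazol-2-yl group, with oxygen in place of the sulfur, or a plain phenyl group would do on this nitrogen.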